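From a Propanoylamino Arm to a Methylcarbamoyl Group

This account rests on a few compounds, and the source may have more. Where it says the series, first, only, none or still open, it means among the compounds named here.

Measured so far:
Compound 1 `CCNC(=O)c1noc(-c2cc(C(C)C)c(O)cc2O)c1-c1cc(CNC(=O)CC)no1`: 78 nM
Compound 2 `CCNC(=O)c1noc(-c2cc(C(C)C)c(O)cc2O)c1-c1cc(C(=O)O)no1`: "not determined" (no result reported)
Compound 3 `CCNC(=O)c1noc(-c2cc(C(C)C)c(O)cc2O)c1-c1cc(C(N)=O)no1`: 79 nM

In a functional assay on HCT-116 cells (Homo sapiens) for inhibition (on this read-out higher numbers stand for weaker inhibition and lower numbers for stronger inhibition), compound 1 gives 78 nM, the lowest of the two numbers in hand. Its nearest neighbour is compound 3, which differs by a carbamoyl in place of (propanoylamino)methyl on an aromatic carbon and gives 79 nM; the step of a 1.0-fold higher number from compound 1 to compound 3 (0.01 log units; within the scatter) lies within the scatter, so the two values cannot be told apart. For compound 2, the acid, no number was reported in this assay.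

Compound 4 `CCNC(=O)c1noc(-c2cc(C(C)C)c(O)cc2O)c1-c1cc(C(=O)NC)no1` has not yet been measured. It differs from compound 1 as follows: methylcarbamoyl in place of (propanoylamino)methyl on an aromatic carbon. Among the compounds with values here, the only measured step that bears on this change is a 1.0-fold higher number from compound 1 to compound 3 (0.01 log units; within the scatter), where the same arm was exchanged for a smaller amide and nothing beyond the scatter resulted. Compound 4 carries a methylcarbamoyl, an amide between those two in size, so the expectation for it in this assay is a step of about a 1.0-fold higher number from compound 1 to compound 4 (0.01 log units; within the scatter), that is, no change beyond the scatter. Compound 4 is therefore estimated at 80 nM, with a range from 40 nM to 160 nM.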

Compound 4, half-maximal inhibitory concentration: 124 nM
Estimate against measurement, compound 4: 1.6-fold (0.19 log units) below; the range from low to high includes it.
By their numbers in this assay, from the lowest: compounds 1, 3 and 4 (each within the scatter of the next).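

In this assay, the position on the five-membered aromatic ring, two ring bonds from the ring atom that bears a large group, now has a third measured amide, and the exchange of (propanoylamino)methyl for methylcarbamoyl gives a 1.6-fold higher number from compound 1 to compound 4 (0.20 log units; within the scatter). Within the data shown here, compound 4 also adds the first comparison on the amide nitrogen itself: methyl in place of hydrogen gives a 1.6-fold higher number from compound 3 to compound 4 (0.20 log units; within the scatter), so an N-methyl group on this carbamoyl and a reversed, longer propanoylamino arm both leave the number within the scatter of the plain carbamoyl of compound 3. No accompanying data bear on why these three amides cannot be told apart.

Every group with a number at this position so far is an amide, so the compounds shown leave open whether an aminomethyl group or a longer chain on the amide nitrogen, such as butylcarbamoyl, would give a step beyond the scatter. They also leave open what a plain methyl group at this position would give, and with it whether any amide is needed there at all.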